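Swapping the Ring Tail on a Stilbene Ether

This account rests on a few compounds, and the source may have more. Where it says the series, first, only, none or still open, it means among the compounds named here.

Measured compounds:
compound 1, `C(=C/c1ccccc1OCCCCN1CCCC1)\c1ccccc1` — 42.9%
compound 2, `C(=C/c1ccccc1OCCCCN1CCNCC1)\c1ccccc1` — 0%
compound 3, `CCN1CCN(CCCCOc2ccccc2/C=C/c2ccccc2)CC1` — 33.3%

In a functional assay on the whole organism with Mus musculus as the target, in the maximal electroshock model, at a dose of 50 mg/kg by the oral route (on this read-out lower numbers stand for less inhibition and higher numbers for more inhibition at the one dose given (going by the name of the read-out)), compound 3 gives 33.3%, the second highest of the three numbers. Its nearest neighbour is compound 1, with a number 9.6 percentage points lower from compound 1 to compound 3 (within the scatter); its furthest is compound 2, with a number 33.3 percentage points higher from compound 2 to compound 3 (beyond the scatter). The three compounds share one core and differ only in the ring amine at the chain end, so all three steps bear on the next change: a number 42.9 percentage points lower from compound 1 to compound 2 (beyond the scatter) and a number 9.6 percentage points lower from compound 1 to compound 3 (within the scatter).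

Compound 4, `OCC1CCCN(CCCCOc2ccccc2/C=C/c2ccccc2)C1`, differs from compound 3 in one place: 3-(hydroxymethyl)piperidin-1-yl in place of 4-ethylpiperazin-1-yl on a saturated chain carbon, four bonds along the chain from an oxygen on an aromatic ring. One exchange of the ring amine at the same position gave a number that stays within the scatter, yet another exchange there gave a number lower by a step beyond the scatter, so the outcome is uncertain. Compound 4 is estimated to give 25% in this assay, within 5% to 45%. This means an expected step of a number 8.3 percentage points lower from compound 3 to compound 4 (within the scatter), a modest loss that may still sit within the scatter.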

Compound 4, a percentage reported as inhibition, in the whole organism at one dose (the size of the read-out at that dose, not a potency): 12.5%
Estimate against measurement, compound 4: 12.5 percentage points above; the measured number falls inside the stated range.
By their numbers in this assay, from the lowest: compound 2; then compound 4; then compounds 3 and 1 (each within the scatter of the next).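

In this assay the 3-(hydroxymethyl)piperidin-1-yl tail falls on neither side of the earlier split, with a number 20.8 percentage points lower from compound 3 to compound 4 (beyond the scatter) and a number 30.4 percentage points lower from compound 1 to compound 4 (beyond the scatter) but also a number 12.5 percentage points higher from compound 2 to compound 4 (beyond the scatter), so this chain end can give an intermediate number as well as a near-equal pair and a complete loss. The change from 4-ethylpiperazin-1-yl keeps the same count of 8 heavy atoms and a six-membered ring, so in this pair the number moves beyond the scatter without any change in tail size. No measurement here explains the difference.

On these data alone, whether the drop belongs to the hydroxymethyl group or to the piperidine ring itself remains open. A plain piperidin-1-yl or a morpholin-4-yl tail at the same place would help separate the two.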